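The source may report more compounds than this note shows. Statements on the series, on what has been measured and on what is new or still open speak of the compounds shown alone.

In an ADME assay on MT4 cells (Homo sapiens) for cytotoxicity, read by MTT assay (on this read-out lower numbers stand for higher toxicity in this test and higher numbers for lower toxicity in this test), compound 1 (`Cc1c(Cc2c(F)cccc2F)nc(SCC(=O)c2ccc(F)cc2)[nH]c1=O`) gives > 62000 nM, which is a limit of the assay and not a number. Compound 2 (`CCc1c(Cc2c(F)cccc2F)nc(SCC(=O)c2ccc(F)cc2)[nH]c1=O`) gives > 60000 nM, which is likewise a limit. Among the compounds with values here, compound 2 therefore has no exact position on this scale, and the only other value available for comparison is also a limit.

The next change leads to compound 3 (`CC(C)c1c(Cc2c(F)cccc2F)nc(SCC(=O)c2ccc(F)cc2)[nH]c1=O`) and is methyl in place of hydrogen on a saturated chain carbon bound to an aromatic carbon and a saturated chain carbon. Methyl replaces hydrogen on a saturated chain carbon bound to an aromatic carbon and a saturated chain carbon, turning ethyl into isopropyl.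

Within the data shown here, one measured step bears on this change, the similar methyl-for-hydrogen replacement seen in a step that the two limits leave unreadable from compound 1 to compound 2. Its size cannot be read, so it offers no evidence of a shift in either direction, and no change beyond the usual scatter is expected in this assay. The estimated change is an at least 1.0-fold lower number from compound 2 to compound 3 (0.01 log units; that floor lies within the scatter). A limit is again the most likely report. Compound 3 is expected at 58000 nM, with an estimated range from 25000 nM to 90000 nM.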

Compound 3, half-maximal cytotoxic concentration: > 58000 nM
Compound 3 ended at the assay's limit (the forecaster's own chance of this, stated with the estimate: 75%); the middle value sits exactly at the limit.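

In this assay compound 3 gives > 58000 nM, which is a limit of the assay. Within the data shown here, with compound 1 and compound 2 also reported as limits, no step among the three can be read. The compounds shown leave open whether methyl, ethyl and isopropyl differ at all on this read-out, and at what concentration each compound would reach its half-maximal cytotoxic effect.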